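A few compounds are considered here, and "the series" means these few. Any claim that something is new, unique, unknown or untested is made for them only; others in the source may bear on it.

Compound 3 `CC(C)S(=O)(=O)N1CCC(CN(C2Cc3cc(C#N)ccc3N(Cc3cncn3C)C2)S(=O)(=O)c2ccccn2)CC1` carries the lowest number of the three measured compounds: in an ADME assay on Caco-2 cells (Homo sapiens) for permeability, in the apical to basolateral direction (on this read-out lower numbers stand for lower permeability and higher numbers for higher permeability), compound 3 gives 0.1 10^-6 cm/s. Compound 1 `Cn1cncc1CN1CC(N(CC2CCN(C(=O)C3CCCC3)CC2)S(=O)(=O)c2ccccn2)Cc2cc(C#N)ccc21` gives 0.5 10^-6 cm/s and compound 2 `Cn1cncc1CN1CC(N(CC2CCN(C(=O)c3ccccc3)CC2)S(=O)(=O)c2ccccn2)Cc2cc(C#N)ccc21` gives 0.5 10^-6 cm/s, with no change at the digits printed from compound 1 to compound 2 (within the scatter). The steps of a 5.0-fold lower number from compound 1 to compound 3 (0.70 log units; beyond the scatter) and a 5.0-fold lower number from compound 2 to compound 3 (0.70 log units; beyond the scatter) both concern the substituent on the amine nitrogen in the ring, a ring that compound 4 no longer contains. Compound 4 `Cn1cncc1CN1CC(N(Cc2ccc(S(C)(=O)=O)cc2)S(=O)(=O)c2ccccn2)Cc2cc(C#N)ccc21` differs from compound 3 as follows: 4-(methylsulfonyl)phenyl in place of 1-(isopropylsulfonyl)piperidin-4-yl on a saturated chain carbon bound to a sulfonamide nitrogen. Within the data shown here, no measured step exchanges the whole saturated ring for an aromatic one, so the two steps bear only loosely. For compound 4, which retains a sulfonyl, a step of a 3.0-fold higher number from compound 3 to compound 4 (0.48 log units; beyond the scatter) is expected, at most a small rise. Compound 4 is estimated at 0.3 10^-6 cm/s, range 0.1 10^-6 cm/s to 1 10^-6 cm/s.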

Compound 4, apparent permeability: 0.2 10^-6 cm/s
Compound 4: the middle estimate sits 1.5-fold (0.18 log units) above what was measured; measured number inside the range.
By their numbers in this assay, from the lowest: compounds 3 and 4 (each within the scatter of the next); then compounds 1 and 2 (each within the scatter of the next).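

At the saturated chain carbon bound to a sulfonamide nitrogen, 4-(methylsulfonyl)phenyl in place of 1-(isopropylsulfonyl)piperidin-4-yl gives a 2.0-fold higher number from compound 3 to compound 4 (0.30 log units; within the scatter) in this assay. The earlier compounds shown here all keep the six-membered non-aromatic ring; this pair shows that the whole group can be exchanged for a six-membered aromatic ring without a step beyond the scatter. No evidence on the reason for this result is available. Open, on these data alone, is whether an amine or a carboxylic acid in place of the methylsulfonyl would separate from compound 3 and compound 4. Also open, as far as these compounds go, is how an unsubstituted phenyl would read here.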